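Swapping the Amide Aryl Group on a Shared Core

The compounds below may be only part of what the source reports. "The series", "measured", "known", "first", "only" and "open" are said of these compounds alone.

Compound 1 `CCOc1ccccc1C(=O)Nc1nc(-c2ccccc2)nc2c1nnn2Cc1ccccc1` gives 1850 nM in an assay (strain Wistar) for displacement of a labelled ligand from adenosine receptor A1 (Rattus norvegicus), read by scintillation counting (on this read-out higher numbers stand for weaker inhibition and lower numbers for stronger inhibition), the highest of the three numbers measured. Compound 2 `O=C(Nc1nc(-c2ccccc2)nc2c1nnn2Cc1ccccc1)C1CC1` gives 7.5 nM, and compound 3 `O=C(Nc1nc(-c2ccccc2)nc2c1nnn2Cc1ccccc1)c1ccc([N+](=O)[O-])cc1` gives 24 nM. Both steps away from compound 1 were large, a 250-fold lower number from compound 1 to compound 2 (2.39 log units; beyond the scatter) and a 77-fold lower number from compound 1 to compound 3 (1.89 log units; beyond the scatter), whereas a 3.2-fold higher number from compound 2 to compound 3 (0.51 log units; beyond the scatter) was modest. Compound 4 `O=C(Nc1nc(-c2ccccc2)nc2c1nnn2Cc1ccccc1)c1ccc(C(F)(F)F)cc1` differs from compound 1 by 4-(trifluoromethyl)phenyl in place of 2-ethoxyphenyl on a carbonyl carbon. The step from compound 1 to compound 3 bears most directly on this change: there too 2-ethoxyphenyl gave way to a phenyl ring carrying a single group, and the number fell sharply. A large lowering of similar size is therefore expected, a 62-fold lower number from compound 1 to compound 4 (1.79 log units; beyond the scatter). Compound 4 is estimated at 30 nM, within a range from 8 nM to 120 nM.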

Compound 4, inhibition constant: 123 nM
Estimate against measurement, compound 4: 4.1-fold (0.61 log units) below, and the stated range ends below it.
By their numbers in this assay, from the lowest: compound 2; then compound 3; then compound 4; then compound 1.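

In this assay the lowering is not tied to the nitro group, since a 15-fold lower number from compound 1 to compound 4 (1.18 log units; beyond the scatter) is still large, but the group on the ring does matter, as a 5.1-fold higher number from compound 3 to compound 4 (0.71 log units; beyond the scatter) makes plain. Cyclopropyl on the carbonyl carbon also keeps a clear lead, with a 16-fold higher number from compound 2 to compound 4 (1.21 log units; beyond the scatter) on moving to the 4-(trifluoromethyl)phenyl ring. No measurement available here accounts for these differences. Open, going by these compounds, is how a plain phenyl ring, a phenyl ring carrying an amine, or a longer chain on the carbonyl carbon would read.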